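Urea nitrogen substituent and cytotoxicity in the series

The source may report more compounds than this note shows. Statements on the series, on what has been measured and on what is new or still open speak of the compounds shown alone.

Compound 1 `CC(C)(C)S(=O)(=O)N(CCCCCCN1C[C@H](O)[C@@H](O)[C@H](O)[C@H]1CO)C1CCCCC1`, compound 2 `NC(=O)N(CCCCCCN1C[C@H](O)[C@@H](O)[C@H](O)[C@H]1CO)C1CCCCC1` and compound 3 `CCCNC(=O)N(CCCCCCN1C[C@H](O)[C@@H](O)[C@H](O)[C@H]1CO)C1CCCCC1` share one core and differ only in the group on the amine nitrogen that also bears the cyclohexyl. In an ADME assay on MDBK cells (Bos taurus) for cytotoxicity, read by MTT assay (on this read-out higher numbers stand for lower toxicity in this test and lower numbers for higher toxicity in this test), compound 1 gives > 500000 nM, which is a limit of the assay. Compound 2 gives > 500000 nM, again a limit. Compound 3 gives > 500000 nM, also a limit. Compound 3 thus stands at the same point as the other two, namely (the limit of > 500000 nM in this assay, at which 3 of the 3 values shown sit). The steps a step that the two limits leave unreadable from compound 1 to compound 2, a step that the two limits leave unreadable from compound 1 to compound 3 and a step that the two limits leave unreadable from compound 2 to compound 3 are therefore unreadable in size.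

Compound 4 `CC(C)(C)NC(=O)N(CCCCCCN1C[C@H](O)[C@@H](O)[C@H](O)[C@H]1CO)C1CCCCC1` differs from compound 3 by tert-butyl in place of propyl on an amide-type nitrogen. Among the compounds with values here, no measured step covers this exact exchange; the nearest, a step that the two limits leave unreadable from compound 2 to compound 3, is itself unreadable, and all three measured values sit at the limit. Expected is no step beyond the scatter, reading a number no higher from compound 3 to compound 4 (the limit leaves the size open). Compound 4 is estimated at 500000 nM, with a range from 300000 nM to 1000000 nM, most probably reported once more as a limit.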

Compound 4, half-maximal cytotoxic concentration: > 500000 nM
Compound 4: a limit, no number; the forecaster's own chance of this, stated with the estimate: 90%; the middle value lies on the limit itself.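

Compound 4 gives > 500000 nM in this assay, again a limit of the assay. No step from compound 1, compound 2 or compound 3 to compound 4 can be read: the limit of > 500000 nM in this assay, at which 4 of the 4 values shown sit.

The compounds shown leave open where any of the four lies beyond that limit, so the groups on the nitrogen cannot be ranked.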